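Series notes: aryl swap on the amide-type nitrogen

The source may hold more compounds than are shown below. What is called first, only, known or untested is meant among the compounds shown, and "the series" means these compounds.

Of the compounds shown here, two have been measured in a functional assay on the whole organism for inhibition, with Lemna aequinoctialis as the target, tested at 10 ug/mL; a higher number here means more inhibition of growth at the concentration tested, a lower number less inhibition of growth. Compound 1 `O=C1Nc2ccc([N+](=O)[O-])cc2/C1=N/NC(=S)Nc1ccccc1C(F)(F)F` gives 10%, and compound 2 `O=C1Nc2ccc([N+](=O)[O-])cc2/C1=N/NC(=S)Nc1ccc(F)cc1` gives 5%. Compound 2 holds the lower of the two numbers, but its distance to compound 1 lies within the scatter, so the two read as alike, both at low growth inhibition. Compound 3 `N#Cc1cccc(NC(=S)N/N=C2\C(=O)Nc3ccc([N+](=O)[O-])cc32)c1` has not been measured; it differs from compound 2 by 3-cyanophenyl in place of 4-fluorophenyl on an amide-type nitrogen. Going by the values given here, no measured pair shows a change of this kind, so nothing tells the size of the step. With both measured compounds sitting low and alike, the step is expected to be small, in either direction or none beyond the scatter. For compound 3 the estimate is 10%, with a range from 0% to 30%. The expected step from compound 2 to compound 3 is a number 5 percentage points higher from compound 2 to compound 3 (within the scatter).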

Compound 3, percent growth inhibition at one concentration: 5%
For compound 3 the middle estimate is 5 percentage points above the measured one; low and high end bracket the measured number.
By their numbers in this assay, from the lowest: compounds 2, 3 and 1 (each within the scatter of the next).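

In this assay, going by these compounds alone, 3-cyanophenyl in place of 4-fluorophenyl on the amide-type nitrogen gives no change at the digits printed from compound 2 to compound 3 (within the scatter) and so provides the first readable step at this position: a nitrile-bearing phenyl ring and a fluorine-bearing one do not separate here. Compound 1, compound 2 and compound 3 now all sit together at low growth inhibition, so none of these three aryl groups lifts the read-out clear of the others. Nothing available explains this flat result.

Still open, as far as these compounds go, is whether this nitrogen can carry anything that separates from these three, such as a phenyl ring bearing an amine or a carboxylic acid, or a saturated alkyl chain in place of the ring. Also open, from the compounds shown here alone, is whether the nitro group on the shared core matters to this read-out.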